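The source may hold more compounds than are shown below. What is called first, only, known or untested is meant among the compounds shown, and "the series" means these compounds.

Measured in a functional assay on CCRF-CEM cells (Homo sapiens) for inhibition, read by MTT assay, with a stated time of 72 h; on this read-out lower numbers stand for stronger inhibition and higher numbers for weaker inhibition:
- compound 1 `COc1cc(NC(C)CCCNC(=O)NNC(=O)Nc2ccc(Cl)cc2)c2ncccc2c1` gives 108000 nM
- compound 2 `COc1cc(NC(C)CCCNC(=O)Nc2cccc(O)c2)c2ncccc2c1` gives 32000 nM
- compound 3 `COc1cc(NC(C)CCCNC(=O)Nc2ccc(C(F)(F)F)cc2)c2ncccc2c1` gives 14000 nM

Compound 1 has the highest of these numbers, making it the weakest of the three. Compound 4 `COc1cc(NC(C)CCCNC(=O)NNC(=O)Nc2cccc(C(F)(F)F)c2)c2ncccc2c1` differs from it by 3-(trifluoromethyl)phenyl in place of 4-chlorophenyl on an amide-type nitrogen, with 3-(trifluoromethyl)phenyl in place of 4-chlorophenyl on an amide-type nitrogen.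

Among the compounds with values here, no measured step makes this exact swap. The closest is a 2.3-fold lower number from compound 2 to compound 3 (0.36 log units; beyond the scatter), a modest change that also exchanges one substituted phenyl for another. The larger steps, a 3.4-fold lower number from compound 1 to compound 2 (0.53 log units; beyond the scatter) and a 7.7-fold lower number from compound 1 to compound 3 (0.89 log units; beyond the scatter), replace more of the molecule and so bear on it less.

A small lowering is therefore expected in this assay, and the expected step is a 2.2-fold lower number from compound 1 to compound 4 (0.33 log units; beyond the scatter) as a rough guide. For compound 4 the estimated value is 50000 nM, with an expected range from 15000 nM to 130000 nM as its limits.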

Compound 4, half-maximal inhibitory concentration: 6900 nM
The estimate for compound 4 lay 7.2-fold (0.86 log units) above the measured number; measured number below the stated range.
By their numbers in this assay, from the lowest: compound 4; then compound 3; then compound 2; then compound 1.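

On the amide-type nitrogen, 3-(trifluoromethyl)phenyl in place of 4-chlorophenyl gives a 16-fold lower number from compound 1 to compound 4 (1.19 log units; beyond the scatter) with the rest of the molecule unchanged, which makes this a large step. The earlier steps shown here changed more of the molecule, whereas this one shows that the aryl group at this place can alone shift the number strongly. Nothing measured here explains why this swap has so large an effect.

On these data alone, whether the trifluoromethyl group or its ring position matters more stays open, as both change at once. So does the outcome with an amine or a carboxylic acid on that phenyl ring.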